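Aryl swap on the ring amine: outlook for compound 4

The compounds below may be only part of what the source reports. "The series", "measured", "known", "first", "only" and "open" are said of these compounds alone.

Values so far in a functional assay on the whole organism (strain Swiss) with Mus musculus as the target, in the maximal electroshock model, with a stated time of 1 h, at a dose of 300 mg/kg by the intraperitoneal route; on this read-out higher numbers stand for a stronger effect at the one dose given and lower numbers for a weaker effect:
compound 1 `COc1cccc(N2CCN(C(=O)C(C)N3C(=O)CCC3=O)CC2)c1` gives 0%
compound 2 `CC(C(=O)N1CCN(c2ccccc2)CC1)N1C(=O)CCC1=O` gives 50%
compound 3 `CC(C(=O)N1CCN(c2ccc(F)cc2)CC1)N1C(=O)CCC1=O` gives 25%

Compound 3 stands second highest of the three: the step of a number 25 percentage points lower from compound 2 to compound 3 (beyond the scatter) sets it below compound 2, and the step of a number 25 percentage points higher from compound 1 to compound 3 (beyond the scatter) sets it above compound 1. Compound 4 `CC(C(=O)N1CCN(c2ccccc2Cl)CC1)N1C(=O)CCC1=O` differs from compound 3 by 2-chlorophenyl in place of 4-fluorophenyl on an amine nitrogen in a ring. Within the data shown here, two measured steps bear on this: the aryl swap a number 25 percentage points higher from compound 1 to compound 3 (beyond the scatter) and the halogen-for-hydrogen step a number 25 percentage points lower from compound 2 to compound 3 (beyond the scatter), both modest and both showing that substituted phenyl groups on this nitrogen trail the bare phenyl of compound 2. Among the measured compounds shown here, no measured compound carries 2-chlorophenyl, so a step of no more than modest size is expected, and the estimate is no change at the digits printed from compound 3 to compound 4 (within the scatter). Compound 4 is therefore expected to give 25% in this assay, within a range of 0% to 50%.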

Compound 4, a percentage reported as activity, at one dose (the size of the read-out at that dose, not a potency): 25%
Estimate against measurement, compound 4: no gap at the digits printed; the measured number falls inside the stated range.
By their numbers in this assay, from the lowest: compound 1; then compounds 3 and 4 (each within the scatter of the next); then compound 2.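

In this assay, swapping 4-fluorophenyl for 2-chlorophenyl on the ring amine nitrogen gives no change at the digits printed from compound 3 to compound 4 (within the scatter), so these two halogen-bearing aryl groups cannot be told apart here. Chloro in place of hydrogen gives a number 25 percentage points lower from compound 2 to compound 4 (beyond the scatter), and 2-chlorophenyl in place of 3-methoxyphenyl gives a number 25 percentage points higher from compound 1 to compound 4 (beyond the scatter), leaving all three substituted phenyl groups shown below the bare phenyl, with no exception among these compounds. No measured evidence accounts for these steps.

Compounds 3 and 4 differ in both halogen and ring position, so neither can be judged alone. Also open, on these data alone, is whether a nitrile or trifluoromethyl on the phenyl would match compound 2 at 50%.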